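The source may hold more compounds than are shown below. What is called first, only, known or untested is meant among the compounds shown, and "the series" means these compounds.

Of the compounds shown here, three of one family have been measured in an ADME assay on 184B5 cells (Homo sapiens) for cytotoxicity, read by MTT assay, with a stated time of 72 h; on this read-out higher numbers stand for weaker inhibition of growth and lower numbers for stronger inhibition of growth. Compound 1, `COc1ccc(OC(=O)Nc2ccc([Se]C#N)cc2)cc1`, gives 19200 nM in this assay. Compound 2, `CCCOC(=O)Nc1ccc([Se]C#N)cc1`, gives 9100 nM. Compound 3, `O=C(Nc1ccc([Se][Se]c2ccc(NC(=O)OCc3ccccc3)cc2)cc1)OCc1ccccc1`, gives 5800 nM. Among these three numbers compound 2 sits between the other two: the gap to compound 1, whose number is higher, lies beyond the usual scatter of such measurements, while the gap to compound 3 lies within it, so those two numbers cannot be told apart.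

The next compound, compound 4, is `CC(C)COC(=O)Nc1ccc([Se]C#N)cc1`. It differs from compound 2 by a single change: methyl in place of hydrogen on a saturated chain carbon bound to two saturated chain carbons. Going by the values given here, no pair of measured compounds shows the effect of exactly this change, so nothing in the numbers so far sets its size or direction. Such a small addition on the chain is expected to leave the number roughly where compound 2 stands, that is, the step from compound 2 to compound 4 in this assay is expected to be a 1.1-fold lower number from compound 2 to compound 4 (0.06 log units; within the scatter), not beyond the scatter. For compound 4 the expected value is 8000 nM, within a range from 3500 nM to 18000 nM.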

Compound 4, concentration for total growth inhibition: 21600 nM
Estimate against measurement, compound 4: 2.7-fold (0.43 log units) below, outside the stated range (above it).
By their numbers in this assay, from the lowest: compounds 3 and 2 (each within the scatter of the next); then compounds 1 and 4 (each within the scatter of the next).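

Placing a methyl on a saturated chain carbon bound to two saturated chain carbons, which turns propyl into isobutyl, is not a silent change: in this assay it gives a 2.4-fold higher number from compound 2 to compound 4 (0.38 log units; beyond the scatter) and so moves the number towards weaker inhibition of growth. Going by these compounds alone, this is the first step in the family that changes only one place, and it shows that this part of the chain can shift the read-out, though it is only one pair of compounds. Nothing measured here accounts for the shift.

The compounds shown leave open whether a longer chain, such as butyl, or a larger branch, such as ethyl, on the same carbon would move the number further in this direction. They also leave open what an amine or a hydroxyl group at that place would do.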